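A few compounds are considered here, and "the series" means these few. Any claim that something is new, unique, unknown or untested is made for them only; others in the source may bear on it.

Compound 1, `CC#CC(CC(=O)O)c1ccc(OCc2ccn3cc(-c4ccc(C5CCCCC5)cc4)nc3c2)cc1`, in an assay on isolated protein for agonist activity at Free fatty acid receptor 1 (Homo sapiens); a higher number here means that more compound is needed for the effect, a lower number that less compound is needed: 559 nM
Compound 2, `CC#CC(CC(=O)O)c1ccc(OCc2ccn3cc(-c4ccc(C(C)C)cc4)nc3c2)cc1`, in this assay: 615 nM
Compound 3, `CC#CC(CC(=O)O)c1ccc(OCc2ccn3cc(-c4ccccc4C)nc3c2)cc1`, in this assay: 459 nM

All three compounds share one core and differ only in the aryl group attached to it. Compound 3 gives the lowest of the three numbers, but its neighbours lie close: a 1.2-fold lower number from compound 1 to compound 3 (0.09 log units; within the scatter) and a 1.3-fold lower number from compound 2 to compound 3 (0.13 log units; within the scatter), so the three values cannot be ordered with any confidence.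

Compound 4, `CC#CC(CC(=O)O)c1ccc(OCc2ccn3cc(-c4cc(F)ccc4F)nc3c2)cc1`, has not yet been measured. Its difference from compound 3 is 2,5-difluorophenyl in place of 2-methylphenyl on an aromatic carbon. Among the measured compounds shown here, the steps that bear on this change are the ones that swap the same aryl group: a 1.1-fold higher number from compound 1 to compound 2 (0.04 log units; within the scatter), a 1.2-fold lower number from compound 1 to compound 3 (0.09 log units; within the scatter) and a 1.3-fold lower number from compound 2 to compound 3 (0.13 log units; within the scatter). Each of these exchanges left the number essentially where it was. For the measured compounds named here, on that basis no step beyond the scatter is expected from compound 3 to compound 4 in this assay, in either direction, although the entering group carries two fluorines that none of the measured compounds shares, so the range is kept wide.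

Compound 4 is therefore estimated at 480 nM, with a range from 200 nM to 1200 nM, which means an expected step of a 1.0-fold higher number from compound 3 to compound 4 (0.02 log units; within the scatter).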

Compound 4, half-maximal effective concentration: 639 nM
For compound 4 the middle estimate is 1.3-fold (0.12 log units) below the measured one; low and high end bracket the measured number.
By their numbers in this assay, from the lowest: compounds 3, 1, 2 and 4 (each within the scatter of the next).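

In this assay, among the compounds shown here, the exchange of 2-methylphenyl for 2,5-difluorophenyl brought fluorine into this aryl group for the first time, and the outcome stayed within the scatter (a 1.4-fold higher number from compound 3 to compound 4 (0.14 log units; within the scatter)), as it did against the two larger para-free comparisons (a 1.0-fold higher number from compound 2 to compound 4 (0.02 log units; within the scatter) and a 1.1-fold higher number from compound 1 to compound 4 (0.06 log units; within the scatter)). The four groups at this aromatic carbon of the five-membered ring therefore cannot be told apart by their numbers, so the flat picture seen among the alkyl-bearing phenyl groups now extends to a phenyl group carrying two fluorines. No information is available that accounts for this result.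

Going by these compounds, all four groups are phenyl rings bearing only alkyl groups or fluorine, with no hydrogen-bond donors or acceptors, so it remains open whether an amine, a hydroxyl or a carboxylic acid on this ring would move the number beyond the scatter. On these data alone, it is also open whether a single fluorine, a methoxy group or a trifluoromethyl group would behave as the 2,5-difluorophenyl group does.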